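The source may hold more compounds than are shown below. What is called first, only, known or untested is meant among the compounds shown, and "the series" means these compounds.

Going by the values given here, compound 3 `COc1cc(Cn2cc(CNC(=O)c3ccc([N+](=O)[O-])o3)nn2)ccc1F` is one of three compounds measured in an ADME assay on Vero cells (Chlorocebus sabaeus) for cytotoxicity; a lower number here means a stronger inhibitor, a higher number a weaker inhibitor. In this assay compound 3 gives 225000 nM. Compound 2 `COc1cc(Cn2cc(CNC(=O)c3ccc([N+](=O)[O-])o3)nn2)ccc1O` gives 224000 nM in this assay, and compound 1 `O=C(NCc1cn(Cc2cccc([N+](=O)[O-])c2)nn1)c1ccc([N+](=O)[O-])o1` gives 326000 nM in this assay. The number for compound 3 sits closest to that of compound 2, with a 1.0-fold higher number from compound 2 to compound 3 (0.00 log units; within the scatter); it sits furthest from compound 1, yet even there a 1.4-fold lower number from compound 1 to compound 3 (0.16 log units; within the scatter). Likewise a 1.5-fold lower number from compound 1 to compound 2 (0.16 log units; within the scatter). All three numbers therefore lie together.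

Compound 4 `O=C(NCc1cn(Cc2ccc([N+](=O)[O-])cc2)nn1)c1ccc([N+](=O)[O-])o1` has not yet been measured in this assay. It differs from compound 3 in one place: 4-nitrophenyl in place of 4-fluoro-3-methoxyphenyl on a saturated chain carbon bound to an aromatic nitrogen. Among the compounds with values here, the step that bears on this change is the one from compound 1 to compound 3, where 4-fluoro-3-methoxyphenyl replaced 3-nitrophenyl on a saturated chain carbon bound to an aromatic nitrogen with a 1.4-fold lower number from compound 1 to compound 3 (0.16 log units; within the scatter). Within the data shown here, compound 4 reverses that kind of exchange, although 4-nitrophenyl enters rather than 3-nitrophenyl, and no measured pair compares 3-nitrophenyl with 4-nitrophenyl directly. Because a 1.4-fold lower number from compound 1 to compound 3 (0.16 log units; within the scatter) stayed within the scatter, compound 4 is expected to give a number near that of compound 3, if anything slightly higher. The expected step is then a 1.2-fold higher number from compound 3 to compound 4 (0.09 log units; within the scatter). Compound 4 is estimated at 280000 nM, within a range from 150000 nM to 520000 nM.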

Compound 4, half-maximal inhibitory concentration: 291000 nM
Compound 4: the middle estimate sits 1.0-fold (0.02 log units) below what was measured; measured number inside the range.
By their numbers in this assay, from the lowest: compounds 2, 3, 4 and 1 (each within the scatter of the next).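

In this assay, going by these compounds alone, the pair of compound 1 and compound 4 gives the first direct comparison of 3-nitrophenyl with 4-nitrophenyl on a saturated chain carbon bound to an aromatic nitrogen, and the step is a 1.1-fold lower number from compound 1 to compound 4 (0.05 log units; within the scatter) with no difference that can be told from the scatter. Exchanging either methoxy-bearing group for 4-nitrophenyl gives the same reading, with a 1.3-fold higher number from compound 3 to compound 4 (0.11 log units; within the scatter) for 4-fluoro-3-methoxyphenyl and a 1.3-fold higher number from compound 2 to compound 4 (0.11 log units; within the scatter) for 4-hydroxy-3-methoxyphenyl, so all four substituted phenyl groups shown at this place lie together in this assay, and none of the compounds goes against that. Nothing available here explains why these groups give such similar numbers.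

From the compounds shown here alone, whether a carboxylic acid or an amine on the phenyl ring, or a longer chain in place of the single saturated chain carbon, would keep the number in this same region remains open. The shared core is also the same in all four compounds, so they say nothing about how a change elsewhere in the molecule would read in this assay.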